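Methylsulfanyl versus methoxy on the pendant aryl of the chromone series

This account rests on a few compounds, and the source may have more. Where it says the series, first, only, none or still open, it means among the compounds named here.

Compounds measured so far in an assay on isolated protein for inhibition of prostaglandin G/H synthase 1 (Mus musculus), tested at 10 ug/mL; on this read-out higher numbers stand for more inhibition at the one concentration tested (going by the name of the read-out) and lower numbers for less inhibition:
compound 1 `NS(=O)(=O)c1ccc(-c2oc3ccccc3c(=O)c2-c2ccccc2)cc1`, 61%
compound 2 `CSc1ccc(-c2c(-c3ccc(S(N)(=O)=O)cc3)oc3ccccc3c2=O)cc1`, 90%
compound 3 `CS(=O)(=O)c1ccc(-c2oc3ccccc3c(=S)c2-c2ccccc2)cc1`, < 5%

Compound 3 sits at a limit of this assay; the record for it is a bound, not a number, and it is shared with the limit of < 5% in this assay, at which 1 of the 3 values shown sits. Among the two numbers that are actual values, compound 2 stands highest, with compound 1 as its nearest neighbour, the step of a number 29 percentage points higher from compound 1 to compound 2 (beyond the scatter) lying beyond the usual scatter. Going by the values given here, that single step is the only measured change that touches the same aromatic carbon, and it shows that a small group in this position can move the read-out by a modest amount.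

The next compound, compound 4 `COc1ccc(-c2c(-c3ccc(S(N)(=O)=O)cc3)oc3ccccc3c2=O)cc1`, differs from compound 2 by methoxy in place of methylsulfanyl on an aromatic carbon. Among the compounds with values here, no measured pair shows a methoxy exchanged for a methylsulfanyl, so the direction of the step has no direct precedent. Both groups are of the same size by heavy-atom count and both carry one acceptor, so the step is expected to be small, though the replacement of sulfur by oxygen is enough of a change that a modest fall toward the value of compound 1 cannot be excluded. The expected step from compound 2 to compound 4 is therefore a number 15 percentage points lower from compound 2 to compound 4 (beyond the scatter), and for compound 4 the expected value in this assay is 75%, with a range from 50% to 92%.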

Compound 4, a percentage reported as inhibition, at one concentration (the size of the read-out at that concentration, not a potency): 84%
Compound 4: the middle estimate sits 9 percentage points below what was measured, within the range that was stated.
By their numbers in this assay, from the lowest: compound 1; then compounds 4 and 2 (each within the scatter of the next). At a limit, below all of these: compound 3.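

In this assay, methoxy in place of methylsulfanyl on the aromatic carbon para to a large group gives a number 6 percentage points lower from compound 2 to compound 4 (within the scatter) and so shows that, at this one concentration, the two groups cannot be told apart on this core. Methoxy in place of hydrogen on the same carbon gives a number 23 percentage points higher from compound 1 to compound 4 (beyond the scatter) and so extends the rise seen earlier with methylsulfanyl to a second group, which means that it is no longer tied to the sulfur-bearing substituent in this pair of compounds. The data shown offer no explanation for either step.

Still open, on these data alone, is whether the number in this assay stays higher, is level or is lower with other groups at this position: an amine, a carboxylic acid or a longer chain such as butoxy could show whether the rise over hydrogen persists once the substituent departs from these two small groups. The read-out is also a single-concentration percentage rather than a potency, so compound 2 and compound 4 may or may not separate in a full concentration series.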